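The compounds below may be only part of what the source reports. "The series", "measured", "known", "first", "only" and "open" are said of these compounds alone.

Working notes on the series. In a functional assay on A549 cells (Homo sapiens) for inhibition, read by CCK-8 assay, with a stated time of 48 h (a lower number here means a stronger inhibitor, a higher number a weaker inhibitor), compound 1 (`COc1cc(-c2ccnc3cc(-c4ccc(Cl)cc4)nn23)cc(OC)c1OC`) gives 3070 nM with chloro on the aromatic carbon that varies here, and compound 2 (`COc1cc(-c2ccnc3cc(-c4ccc(C(F)(F)F)cc4)nn23)cc(OC)c1OC`) gives 2070 nM with trifluoromethyl at that carbon. Compound 3 (`C=Cc1ccc(-c2cc3nccc(-c4cc(OC)c(OC)c(OC)c4)n3n2)cc1`) carries vinyl there and gives 1030 nM in the same read-out. It stands within the scatter of compound 2 and beyond the scatter of compound 1, though only modestly.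

Compound 4 (`COc1cc(-c2ccnc3cc(-c4ccc(-c5cnn(C)c5)cc4)nn23)cc(OC)c1OC`) has 1-methyl-1H-pyrazol-4-yl in place of vinyl on an aromatic carbon of a six-membered aromatic ring of carbon only, para to a large group (1-methyl-1H-pyrazol-4-yl in place of vinyl on an aromatic carbon). Three measured exchanges at this carbon bear on the change: a 1.5-fold lower number from compound 1 to compound 2 (0.17 log units; within the scatter) and a 2.0-fold lower number from compound 2 to compound 3 (0.30 log units; within the scatter) stay within the scatter, while a 3.0-fold lower number from compound 1 to compound 3 (0.47 log units; beyond the scatter) goes modestly beyond it. None of these exchanges brings in a ring, so they guide the expectation only loosely.

Resting on the small size of those steps, no step beyond the scatter is expected in this assay and neither direction is clearly favoured. The expected change is a 1.2-fold higher number from compound 3 to compound 4 (0.07 log units; within the scatter) as a working figure. For compound 4 the estimate is 1200 nM with an expected range from 350 nM to 4000 nM in this assay.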

Compound 4, half-maximal inhibitory concentration: 1150 nM
Compound 4: the middle estimate sits 1.0-fold (0.02 log units) above what was measured; the measured number falls inside the stated range.
By their numbers in this assay, from the lowest: compounds 3, 4, 2 and 1 (each within the scatter of the next, the first and the last beyond it).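

In this assay, for the compounds shown here, this carbon accepts a ring for the first time: 1-methyl-1H-pyrazol-4-yl, with 6 heavy atoms against the 2 of vinyl, gives a 1.1-fold higher number from compound 3 to compound 4 (0.05 log units; within the scatter), so the larger group and its hydrogen-bond acceptors leave no readable mark against vinyl. The comparison with trifluoromethyl gives a 1.8-fold lower number from compound 2 to compound 4 (0.26 log units; within the scatter), also without separating the two, while the comparison with chloro gives a 2.7-fold lower number from compound 1 to compound 4 (0.43 log units; beyond the scatter), so compound 1 stands modestly apart from both compound 3 and compound 4, and the ring extends what vinyl already showed rather than adding a new level of effect. No supporting measurement is available to explain why these groups give such closely spaced numbers.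

As far as these compounds go, whether an amine, a carboxylic acid or a longer chain at this carbon would move the number beyond the scatter of compound 3 remains open, as does whether the methyl on the pyrazole contributes anything. From the compounds shown here alone, all four compounds share the rest of their structure, so it is also open whether this narrow spread would persist with a different group elsewhere on the core.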